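Aryl replacement and microsomal clearance in the sulfonamide series

The compounds below may be only part of what the source reports. "The series", "measured", "known", "first", "only" and "open" are said of these compounds alone.

Measured compounds:
compound 1, `Nc1ccc(S(=O)(=O)N2CCN(c3ncc(C(O)(C(F)(F)F)C(F)(F)F)cc3C#CCCO)CC2)cn1`: < 14 mL.min-1.g-1 (a limit)
compound 2, `Nc1ccc(S(=O)(=O)N2CCN(c3ncc(C(O)(C(F)(F)F)C(F)(F)F)cc3-c3cncc(F)c3)CC2)cn1`: 24 mL.min-1.g-1

In an ADME assay (liver) for metabolic stability, with Liver microsome (Homo sapiens) as the target, using microsomes and NADPH, with a stated time of 30 min, tested at 1 uM (a higher number here means faster removal of the compound, a lower number slower removal), compound 1 returns only a limit, < 14 mL.min-1.g-1, as noted at the limit of < 14 mL.min-1.g-1 in this assay, at which 1 of the 2 values shown sits. In this assay, for the measured compounds named here, compound 2 gives 24 mL.min-1.g-1, the only number in the set. The value of compound 1 is a limit. Compound 2 therefore cannot be ranked against compound 1. Going by the values given here, the single measured step, an at least 1.7-fold higher number from compound 1 to compound 2 (0.23 log units; that floor lies within the scatter), lies within the usual scatter.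

Compound 3, `Nc1ccc(S(=O)(=O)N2CCN(c3ncc(C(O)(C(F)(F)F)C(F)(F)F)cc3-c3cccc4[nH]ncc34)CC2)cn1`, is not yet measured. It differs from compound 2 by 1H-indazol-4-yl in place of 5-fluoropyridin-3-yl on an aromatic carbon. Among the compounds with values here, no measured step involves 1H-indazol-4-yl, and the one step available, an at least 1.7-fold higher number from compound 1 to compound 2 (0.23 log units; that floor lies within the scatter), is itself within the scatter, so the expected change for compound 3 in this assay is a 1.3-fold higher number from compound 2 to compound 3 (0.10 log units; within the scatter), no more than scatter in either direction. Compound 3 is therefore estimated at 30 mL.min-1.g-1, with a range from 12 mL.min-1.g-1 to 75 mL.min-1.g-1.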

Compound 3, intrinsic clearance in microsomes: 42 mL.min-1.g-1
Compound 3: middle estimate off by 1.4-fold (0.15 log units), on the low side; the range from low to high includes it.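

In this assay, two aromatic groups can now be compared at this carbon, ortho to a large group: the exchange of 5-fluoropyridin-3-yl for 1H-indazol-4-yl gives a 1.8-fold higher number from compound 2 to compound 3 (0.24 log units; within the scatter), so the two do not separate here. Against 4-hydroxybut-1-yn-1-yl, 1H-indazol-4-yl gives the first step in the series beyond the scatter, an at least 3.0-fold higher number from compound 1 to compound 3 (0.47 log units; beyond the scatter), while the floor of the step to 5-fluoropyridin-3-yl stayed within it. That step starts from a limit, the value of compound 1, and its full size cannot be read: the limit of < 14 mL.min-1.g-1 in this assay, at which 1 of the 3 values shown sits.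

The compounds shown leave open how an unsubstituted phenyl ring or an aliphatic amine at this carbon would read in this assay. On these data alone, whether the hydrogen-bond donor of 1H-indazol-4-yl has any part in the result also remains open.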